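From a tert-Butyl Ketone to a Difluorophenyl Ketone

The source may report more compounds than this note shows. Statements on the series, on what has been measured and on what is new or still open speak of the compounds shown alone.

Three compounds on one shared core were tested in a functional assay on WI-38 VA13 cells (Homo sapiens) for cytotoxicity; a higher number here means that more compound is needed for the effect, a lower number that less compound is needed. Compound 1 `CN(C)c1c(C(=O)c2ccccc2)sc2nc(-c3cccs3)ccc12` reaches only a limit in this assay, > 4 ug/mL. Compound 2 `COc1ccc(OC)c(C(=O)c2sc3nc(-c4cccs4)ccc3c2N)c1` gives 0.079 ug/mL in this assay. Compound 3 `CC(C)(C)C(=O)c1sc2nc(-c3cccs3)ccc2c1N` gives 0.57 ug/mL in this assay, the highest of the two numbers, with compound 2 as its nearest neighbour at a lower number beyond the scatter. Compound 4 `Nc1c(C(=O)c2ccc(F)c(F)c2)sc2nc(-c3cccs3)ccc12` awaits measurement and differs from compound 3 by 3,4-difluorophenyl in place of tert-butyl on a carbonyl carbon. Compound 2, which also bears a six-membered aromatic ring on its carbonyl carbon, gives 0.079 ug/mL, whereas compound 3 gives 0.57 ug/mL. On that basis the expected step, a 3.8-fold lower number from compound 3 to compound 4 (0.58 log units; beyond the scatter), is toward a lower number beyond the scatter. For compound 4 the estimated value in this assay is 0.15 ug/mL, within a range from 0.04 ug/mL to 0.6 ug/mL.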

Compound 4, half-maximal effective concentration: > 4 ug/mL
Compound 4: a limit, no number; the forecaster's own chance of this, stated with the estimate: 5%; middle value at least 26-fold (1.42 log units) away from the limit.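

In this assay, 3,4-difluorophenyl in place of tert-butyl on a carbonyl carbon brings an at least 7.0-fold higher number from compound 3 to compound 4 (0.84 log units; beyond the scatter). A six-membered aromatic ring at this position therefore does not by itself give a low number, although compound 2, which also carries one, gives 0.079 ug/mL. The value of compound 4 is a limit and not a number, so the size of this step is only a lower bound: the limit of > 4 ug/mL in this assay, at which 2 of the 4 values shown sit.

The compounds shown leave open what on the ring separates compound 2 from compound 4. On these data alone, how an amine or a carboxylic acid on that ring, or a longer chain in place of tert-butyl, would behave also remains open.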